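Trifluoromethyl to difluoromethyl on compound 1

The source may hold more compounds than are shown below. What is called first, only, known or untested is meant among the compounds shown, and "the series" means these compounds.

In an ADME assay on a cell-free system (plasma, Mus musculus) for protein binding (on this read-out lower numbers stand for a smaller free fraction and higher numbers for a larger free fraction), compound 1 (`Cn1cc(-c2ccc(C(F)(F)F)cc2)c2cc(F)c(C(=O)NS(=O)(=O)C3CC3)cc21`) gives 0.0035 as its reading. Compound 2 (`Cn1cc(-c2ccc(C(F)(F)F)cc2)c2ccc(C(=O)NS(=O)(=O)C3CC3)cc21`) gives 0.004 and compound 3 (`Cn1cc(-c2ccc(C(F)(F)F)cc2)c2cc(F)c(C(=O)NS(C)(=O)=O)cc21`) gives 0.005 on the same read-out. Compound 1 stands within the scatter of both.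

Compound 4 (`Cn1cc(-c2ccc(C(F)F)cc2)c2cc(F)c(C(=O)NS(=O)(=O)C3CC3)cc21`) carries difluoromethyl where compound 1 carries trifluoromethyl (hydrogen in place of fluoro on a saturated chain carbon bound to an aromatic carbon and two fluorine atoms) with hydrogen in place of fluoro on a saturated chain carbon bound to an aromatic carbon and two fluorine atoms.

Within the data shown here, no measured step touches this group. The two available steps lie elsewhere on compound 1, namely hydrogen in place of fluoro on an aromatic carbon (a 1.1-fold higher number from compound 1 to compound 2 (0.06 log units; within the scatter)) and methyl in place of cyclopropyl on a sulfonyl sulfur (a 1.4-fold higher number from compound 1 to compound 3 (0.15 log units; within the scatter)). Both lie within the scatter, so they give only indirect support for expecting no real movement in this assay here. The estimated step (a 1.3-fold higher number from compound 1 to compound 4 (0.11 log units; within the scatter)) is expected to stay within the scatter. Compound 4 is estimated at 0.0045 with an expected range from 0.003 to 0.008 on this read-out.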

Compound 4, unbound fraction: 0.007
Estimate against measurement, compound 4: 1.6-fold (0.19 log units) below; the range from low to high includes it.
By their numbers in this assay, from the lowest: compounds 1, 2, 3 and 4 (each within the scatter of the next).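

In this assay, among these compounds, the step of a 2.0-fold higher number from compound 1 to compound 4 (0.30 log units; within the scatter) is the first reading on the trifluoromethyl group itself, and it stays within the scatter. All three single changes shown on compound 1 now lie within the scatter, including this one on the 4-(trifluoromethyl)phenyl group, so the free fraction shows no real movement with hydrogen in place of fluoro at this place. No supporting measurement bears on the size of this step.

Going by these compounds, whether a nitrile, a methyl or a carboxylic acid in place of trifluoromethyl would also stay within the scatter remains open. Also open, on these data alone, is whether difluoromethyl would read the same when combined with methyl in place of cyclopropyl on the sulfonyl sulfur.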